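Three Compounds Measured, a Fourth Still to Come

The source may report more compounds than this note shows. Statements on the series, on what has been measured and on what is new or still open speak of the compounds shown alone.

Compound 1 `CCCCCc1ccc(-c2cn(C[C@H](O)[C@H]3OC(=O)C(OCc4ccccc4)=C3OCc3ccccc3)nn2)cc1` gives 9010 nM in a functional assay on MCF7 cells (Homo sapiens) for antiproliferative activity, read by MTT assay, with a stated time of 72 h; a lower number here means a stronger inhibitor, a higher number a weaker inhibitor.
Compound 2 `O=C1O[C@H]([C@@H](O)Cn2cc(CNS(=O)(=O)c3ccc(F)cc3)nn2)C(OCc2ccccc2)=C1OCc1ccccc1` gives 26800 nM in this assay.
Compound 3 `O=C1O[C@H]([C@@H](O)Cn2cc(C3CC3)nn2)C(OCc2ccccc2)=C1OCc1ccccc1` gives 25900 nM in this assay.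

Compound 3 holds the second highest of the three numbers: against compound 2 the difference is a 1.0-fold lower number from compound 2 to compound 3 (0.01 log units; within the scatter), while against compound 1 it is a 2.9-fold higher number from compound 1 to compound 3 (0.46 log units; beyond the scatter). Compound 4 `O=C1O[C@H]([C@@H](O)Cn2cc(-c3cc(F)cc(F)c3)nn2)C(OCc2ccccc2)=C1OCc1ccccc1` differs from compound 3 by 3,5-difluorophenyl in place of cyclopropyl on an aromatic carbon. The step that bears on this is a 2.9-fold higher number from compound 1 to compound 3 (0.46 log units; beyond the scatter), where 4-pentylphenyl at the same position went with the lower number. A modest downward step is therefore expected, a 2.2-fold lower number from compound 3 to compound 4 (0.33 log units; beyond the scatter), though the entering 3,5-difluorophenyl is not 4-pentylphenyl, so the full size of that earlier step is not assumed. Compound 4 is estimated at 12000 nM, with a range from 5500 nM to 26000 nM.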

Compound 4, half-maximal inhibitory concentration: 27700 nM
Compound 4: the middle estimate sits 2.3-fold (0.36 log units) below what was measured, outside the stated range (above it).
By their numbers in this assay, from the lowest: compound 1; then compounds 3, 2 and 4 (each within the scatter of the next).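

In this assay, 3,5-difluorophenyl on this aromatic carbon cannot be told apart from cyclopropyl (a 1.1-fold higher number from compound 3 to compound 4 (0.03 log units; within the scatter)) or from (((4-fluorophenyl)sulfonyl)amino)methyl (a 1.0-fold higher number from compound 2 to compound 4 (0.01 log units; within the scatter)), so an aromatic ring here does not by itself bring the lower number. Only 4-pentylphenyl stands apart (a 3.1-fold higher number from compound 1 to compound 4 (0.49 log units; beyond the scatter)), which ties the lower number to that one group among the four shown. Nothing available explains this result.

On these data alone, whether the pentyl chain itself matters stays open. A plain phenyl, or a phenyl carrying a shorter chain or an amine, would separate the chain from the ring.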